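From methylsulfanyl to pentyloxy, starting at a limit

The source may hold more compounds than are shown below. What is called first, only, known or untested is meant among the compounds shown, and "the series" means these compounds.

Measured in an ADME assay on BCBL1 cells (Homo sapiens) for cytotoxicity, with a stated time of 7 days; a higher number here means that more compound is tolerated, a lower number that less compound is tolerated:
- Compound 1 `Nc1nc(NCc2ccccc2)c2ncn(/C=C3/CC3(CO)CO)c2n1`: 19900 nM
- Compound 2 `Nc1nc(NC2CCCC2)c2ncn(/C=C3/CC3(CO)CO)c2n1`: 71700 nM
- Compound 3 `CSc1nc(N)nc2c1ncn2/C=C1/CC1(CO)CO`: > 20000 nM (a limit, not a number)

Compound 3 has no exact number and stands at the limit of > 20000 nM in this assay, at which 1 of the 3 values shown sits. Compound 4 `CCCCCOc1nc(N)nc2c1ncn2/C=C1/CC1(CO)CO` has not been measured. It differs from compound 3 by pentyloxy in place of methylsulfanyl on an aromatic carbon, with pentyloxy in place of methylsulfanyl on an aromatic carbon.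

Two measured steps change that same carbon: a number no lower from compound 1 to compound 3 (the limit leaves the size open) and a step that the limit leaves unreadable from compound 2 to compound 3. The limit hides the size of both. Among the compounds with values here, the only readable step, a 3.6-fold higher number from compound 1 to compound 2 (0.56 log units; beyond the scatter), swaps a group on a nitrogen instead.

A modest step is therefore expected in this assay, leaning only slightly upward, because of a 3.6-fold higher number from compound 1 to compound 2 (0.56 log units; beyond the scatter). The expected change is a step that the limit leaves unreadable from compound 3 to compound 4. For compound 4 the estimated value is 30000 nM, with an expected range from 10000 nM to 90000 nM.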

Compound 4, half-maximal cytotoxic concentration: > 20000 nM
Compound 4 gave a limit, no number; the forecaster's own chance of this, stated with the estimate: 40%; the middle value is on the limit's open side.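

In this assay compound 4 gives > 20000 nM, which is a limit and not a number. Pentyloxy on this aromatic carbon therefore joins methylsulfanyl as a second group that reads only as a limit, and against benzylamino at the same carbon there is a number no lower from compound 1 to compound 4 (the limit leaves the size open). None of the steps to compound 4 can be read for size, because the values sit at one limit: the limit of > 20000 nM in this assay, at which 2 of the 4 values shown sit.

On these data alone, whether compound 3 and compound 4 differ at all stays open, as both exact values lie out of reach. Also open, as far as these compounds go, is how a methoxy group, a longer alkoxy chain or a free amine on this carbon would read in this assay.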